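The source may hold more compounds than are shown below. What is called first, only, known or untested is meant among the compounds shown, and "the series" means these compounds.

Measured compounds:
compound 1 `O=C(Nc1ccc(S(=O)(=O)N2CCOCC2)c2ccccc12)c1ccccc1` — 7750 nM
compound 2 `CN1CCN(S(=O)(=O)c2ccc(NC(=O)c3ccccc3)c3ccccc23)CC1` — > 30000 nM
compound 3 `Cc1ccccc1C(=O)Nc1ccc(S(=O)(=O)NC2CCN(C(=O)CO)CC2)c2ccccc12` — 5.4 nM

In an assay on L1.2 cells for binding affinity to C-C chemokine receptor type 8 (Homo sapiens) (a lower number here means a stronger inhibitor, a higher number a weaker inhibitor), compound 3 gives the lowest of the two numbers; compound 1 gives the higher number, a step well beyond the scatter. For compound 2 the assay reports only (the limit of > 30000 nM in this assay, at which 1 of the 3 values shown sits), a limit and not a number. Among the compounds with values here, the one measured step, an at least 3.8-fold higher number from compound 1 to compound 2 (0.58 log units; beyond the scatter), is at least modest and concerns the ring on the sulfonyl sulfur, a different part of the shared core.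

Compound 4 `Cc1ccccc1C(=O)Nc1ccc(S(=O)(=O)NC2CCN(C(=O)N3CCCC3)CC2)c2ccccc12` differs from compound 3 in pyrrolidin-1-yl in place of hydroxymethyl on a carbonyl carbon. No measured step touches the carbonyl carbon of the ring nitrogen, so there is no direct precedent for this change in this assay, and nothing in the shown values says which direction the number should move. A step of modest size, in either direction and possibly within the scatter, is expected: a 1.9-fold higher number from compound 3 to compound 4 (0.27 log units; within the scatter). Compound 4 is therefore estimated at 10 nM, with a range from 3 nM to 40 nM.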

Compound 4, inhibition constant: 1.1 nM
Estimate against measurement, compound 4: 9.1-fold (0.96 log units) above; measured number outside the range, below it.
By their numbers in this assay, from the lowest: compound 4; then compound 3; then compound 1. At a limit, above all of these: compound 2.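

In this assay, within the data shown here, the step of a 4.9-fold lower number from compound 3 to compound 4 (0.69 log units; beyond the scatter) gives the first reading at the carbonyl carbon on the amide-type nitrogen in a ring, and it shows that this place responds to the group it carries. Hydroxymethyl, with its hydrogen-bond donor, is not needed for a low number in this pair, as pyrrolidin-1-yl has 0 hydrogen-bond donors and the number still falls. No measurement shown here explains this step.

The pair cannot separate the contribution of the five-membered ring from that of the nitrogen bound to the carbonyl carbon, a question that an open-chain dimethylamino group or a cyclopentyl group at this place would address. From the compounds shown here alone, how a larger piperidin-1-yl ring or a carboxylic acid chain would read at this carbonyl carbon also remains open.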